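The source may hold more compounds than are shown below. What is called first, only, known or untested is meant among the compounds shown, and "the series" means these compounds.

Compound 1, `COc1ccc(NC(=O)NCCNS(=O)(=O)c2ccc(-c3ccccc3OCc3ccccc3)s2)cc1`, was tested in a functional assay on HeLa cells (Homo sapiens) for inhibition, read by CCK-8 assay, with a stated time of 48 h; a higher number here means a weaker inhibitor, a lower number a stronger inhibitor. In that test compound 1 gives only > 50000 nM, which is a limit of the assay rather than a number. A second measured compound, compound 2, `O=C(NCCNS(=O)(=O)c1ccc(-c2ccccc2Oc2ccc([N+](=O)[O-])c([N+](=O)[O-])c2)s1)Nc1ccc([N+](=O)[O-])cc1`, was tested in the same way. In this assay compound 2 gives > 20000 nM, again a limit and not a number. So compound 1 stands at one of two limits: one of the two values sits at the limit of > 50000 nM in this assay, at which 1 of the 2 values shown sits, the other at the limit of > 20000 nM in this assay, at which 1 of the 2 values shown sits, and no measured step between two compounds exists here.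

Compound 3, `O=C(NCCNS(=O)(=O)c1ccc(-c2ccccc2OCc2ccccc2)s1)Nc1cc(Cl)cc(Cl)c1`, differs from compound 1 in one place: 3,5-dichlorophenyl in place of 4-methoxyphenyl on an amide-type nitrogen. Among the compounds with values here, with both measured values being limits, no measured step guides the size of this change. The step of a number no higher from compound 1 to compound 3 (the limit leaves the size open) is expected to be none beyond the scatter. Compound 3 is therefore expected to give about 50000 nM, within 10000 nM to 200000 nM, most likely again reported only as a limit.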

Compound 3, half-maximal inhibitory concentration: > 20000 nM
Compound 3: only a limit was reported; the forecaster's own chance of this, stated with the estimate: 75%; the middle value lies beyond the limit too.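

Compound 3 gives > 20000 nM, which is a limit and not a number. Compound 1 gives > 50000 nM, also a limit, and the step between these two compounds cannot be read. The compounds shown leave open whether exchanging 4-methoxyphenyl for 3,5-dichlorophenyl changes inhibition at all.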